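Changing the Amine Arm of Compound 1

This account rests on a few compounds, and the source may have more. Where it says the series, first, only, none or still open, it means among the compounds named here.

Compound 1 `CCN1CCN(Cc2c(OC)cc(Oc3cccc(Nc4ccccc4)c3)cc2OC)CC1` — in a functional assay on SW-620 cells (Homo sapiens) for inhibition, read by MTT assay, with a stated time of 72 h (on this read-out higher numbers stand for weaker inhibition and lower numbers for stronger inhibition), compound 1 gives > 20000 nM, which is only a limit of the assay.
Compound 2 `CNCc1c(OC)cc(Oc2cccc(Nc3ccccc3)c2)cc1OC` — compound 2 gives 15000 nM.
Compound 3 `COc1cc(Oc2cccc(Nc3ccccc3)c2)cc(OC)c1CNCCNC(C)=O` — compound 3 gives 11900 nM.

All three differ only in the group on a saturated chain carbon bound to an aromatic carbon of the shared core. For compound 1 no number is known; it sits at the limit of > 20000 nM in this assay, at which 1 of the 3 values shown sits. The steps of an at least 1.3-fold lower number from compound 1 to compound 2 (0.12 log units; that floor lies within the scatter) and an at least 1.6-fold lower number from compound 1 to compound 3 (0.22 log units; that floor lies within the scatter) both start from that limit, and their floors lie within the scatter; the step of a 1.3-fold lower number from compound 2 to compound 3 (0.10 log units; within the scatter) also lies within the scatter, so the three compounds cannot be ranked.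

Compound 4 `COc1cc(Oc2cccc(Nc3ccccc3)c2)cc(OC)c1CN[C@H](C)c1ccccc1` is not yet measured. It differs from compound 1 as follows: (1-phenylethyl)amino in place of 4-ethylpiperazin-1-yl on a saturated chain carbon bound to an aromatic carbon. As in compound 2 and compound 3, the 4-ethylpiperazin-1-yl group gives way to an amine carrying a hydrogen on nitrogen. The two steps from compound 1 bear on the change and both point only to a small lowering of uncertain size. Compound 4 is therefore expected to give about 10000 nM in this assay, between 4000 nM and 25000 nM. The expected step of an at least 2.0-fold lower number from compound 1 to compound 4 (0.30 log units; that floor lies within the scatter) is a modest lowering, possibly no larger than the scatter.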

Compound 4, half-maximal inhibitory concentration: 18700 nM
Compound 4: the middle estimate sits 1.9-fold (0.27 log units) below what was measured, and the stated range covers the measured number.
By their numbers in this assay, from the lowest: compounds 3, 2 and 4 (each within the scatter of the next). At a limit, above all of these: compound 1.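

Placing 1-phenylethyl on the amine nitrogen brings a six-membered aromatic ring of carbon only into this part of the molecule, something neither methyl nor 2-acetamidoethyl carries, yet the read-out does not separate the compounds: the data give a 1.2-fold higher number from compound 2 to compound 4 (0.10 log units; within the scatter) and a 1.6-fold higher number from compound 3 to compound 4 (0.20 log units; within the scatter). So in this assay, compounds 2, 3 and 4 cannot be ranked, and these three groups on the amine nitrogen, which differ widely in their atoms, show no difference that can be told from the scatter. The remaining step, an at least 1.0-fold lower number from compound 1 to compound 4 (0.02 log units; that floor lies within the scatter), starts from a limit and gives only a floor, so it cannot show how far compound 4 truly lies from compound 1: the limit of > 20000 nM in this assay, at which 1 of the 4 values shown sits.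

From the compounds shown here alone, it remains open whether any group on this amine nitrogen can move the number beyond the scatter, for instance a carboxylic acid at the end of a longer chain, or a plain amine with no carbon group on its nitrogen. Going by these compounds, the mirror-image form of the 1-phenylethyl group also remains open, as compound 4 shows only one of the two arrangements at its stereocentre.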